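This account rests on a few compounds, and the source may have more. Where it says the series, first, only, none or still open, it means among the compounds named here.

Measured in an ADME assay on Jurkat cells (Homo sapiens) for cytotoxicity, read by MTT assay, with a stated time of 72 h; a higher number here means a weaker inhibitor, a lower number a stronger inhibitor

compound 1 `COC(=O)c1cnc(Oc2ccc3c(c2)B(O)OC3)cn1` gives 7590 nM
compound 2 `NC(=O)c1cnc(Oc2ccc3c(c2)B(O)OC3)cn1` gives 48200 nM
compound 3 `CN(C)C(=O)c1cnc(Oc2ccc3c(c2)B(O)OC3)cn1` gives > 100000 nM as a limit of the assay

Compound 3 stands at a limit of the assay (> 100000 nM) and not at a number.

Compound 4 `CCOC(=O)c1cnc(Oc2ccc3c(c2)B(O)OC3)cn1` is unmeasured and differs from compound 3 as follows (ethoxy in place of dimethylamino on a carbonyl carbon): ethoxy in place of dimethylamino on a carbonyl carbon.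

Within the data shown here, three measured steps bear on this change. The closest is large (an at least 13-fold higher number from compound 1 to compound 3 (1.11 log units; beyond the scatter)), and compound 1 also holds an alkoxy group on the same carbonyl carbon, methoxy rather than ethoxy. The other two are a modest step (a 6.4-fold higher number from compound 1 to compound 2 (0.80 log units; beyond the scatter)) and an at least modest one (an at least 2.0-fold higher number from compound 2 to compound 3 (0.31 log units; beyond the scatter)). All three run the same way, with the number rising from methoxy through amino to dimethylamino, and none of these compounds goes against that.

In this assay a large fall in the number is therefore expected, with compound 4 expected to land near compound 1 (7590 nM) on the shared core. The expected move is an at least 14-fold lower number from compound 3 to compound 4 (1.15 log units; beyond the scatter) as estimated here. The estimate for compound 4 is 7000 nM with an expected range from 2800 nM to 18000 nM for the measurement.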

Compound 4, half-maximal inhibitory concentration: 16800 nM
The estimate for compound 4 lay 2.4-fold (0.38 log units) below the measured number; the range from low to high includes it.
By their numbers in this assay, from the lowest: compound 1; then compound 4; then compound 2. At a limit, above all of these: compound 3.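

In this assay, among these compounds, the alkoxy chain on this carbonyl carbon matters as well as the type of group attached there: going from methoxy to ethoxy gives a 2.2-fold higher number from compound 1 to compound 4 (0.35 log units; beyond the scatter), a change that the earlier compounds, with only one alkoxy group among them, could not show. The ethoxy ester nevertheless keeps a lower number than the amino compound, a 2.9-fold lower number from compound 2 to compound 4 (0.46 log units; beyond the scatter), so among the three compounds with numbers the order runs compound 1, compound 4, compound 2, and neither ester goes against it. Compound 3 stands at a limit of the assay and not at a number, so an at least 5.9-fold lower number from compound 3 to compound 4 (0.77 log units; beyond the scatter) gives only a minimum size for the change from dimethylamino to ethoxy: the limit of > 100000 nM in this assay, at which 1 of the 4 values shown sits.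

Two ester chains cannot show whether a longer chain such as propoxy, or a branched one such as isopropoxy, would continue the rise seen from methoxy to ethoxy. Also open, on these data alone, is where a carboxylic acid or a methylamino group on the same carbonyl carbon would fall relative to the esters and to the amino and dimethylamino compounds.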